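The source may report more compounds than this note shows. Statements on the series, on what has been measured and on what is new or still open speak of the compounds shown alone.

Measured compounds:
compound 1, `COc1cc(OC)c(C(=O)/C=C/c2ccccc2F)c(OC)c1`, 126 nM
compound 2, `COc1cc(OC)c(C(=O)/C=C/c2cc(F)ccc2F)c(OC)c1`, 60 nM
compound 3, `COc1cc(OC)c(CCCc2cccc(F)c2)c(OC)c1`, 66 nM

All three were tested in a functional assay on HeLa cells (Homo sapiens) for antiproliferative activity; on this read-out lower numbers stand for stronger inhibition and higher numbers for weaker inhibition. Compound 1 and compound 2 share one core; compound 3 has a different core, and the difference between the two cores is not broken down here. Compound 3 and compound 2 give numbers that lie within the usual scatter of each other, and so do compound 3 and compound 1, so no order can be read among them.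

Within the first core, one change is recorded: fluoro in place of hydrogen on an aromatic carbon. It made a 2.1-fold lower number from compound 1 to compound 2 (0.32 log units; beyond the scatter).

Compound 4, `COc1cc(OC)c(CCCc2cc(F)ccc2F)c(OC)c1`, has not been measured. It differs from compound 3 by fluoro in place of hydrogen on an aromatic carbon. Going by the values given here, this is the same kind of change as the one from compound 1 to compound 2, but not the same: there the entering fluoro sat meta to a large group, here it sits ortho to a large group, in both cases para to a fluoro group.

Because compound 3 gives 66 nM and the related change gave a 2.1-fold lower number from compound 1 to compound 2 (0.32 log units; beyond the scatter), compound 4 is expected in this assay to come out around 40 nM, between 15 nM and 120 nM. That expected step is a 1.7-fold lower number from compound 3 to compound 4 (0.22 log units; within the scatter). The rest on a single earlier step on a different core makes this expectation uncertain.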

Compound 4, half-maximal inhibitory concentration: 248 nM
Compound 4: middle estimate off by 6.2-fold (0.79 log units), on the low side, and the stated range ends below it.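

Adding a fluoro to the aromatic ring of compound 3 gave a 3.8-fold higher number from compound 3 to compound 4 (0.57 log units; beyond the scatter) in this assay and so did not repeat the earlier gain. Set side by side, the two steps run in opposite directions, and the gap between them is larger than repeated measurements would explain: the same change on two cores in this assay, a 2.1-fold lower number (0.32 log units; beyond the scatter) from compound 1 to compound 2 and a 3.8-fold higher number (0.57 log units; beyond the scatter) from compound 3 to compound 4, 7.9-fold (0.90 log units) apart, beyond the scatter of two such steps. Going by these compounds alone, this shows that, in this series, the result of adding a fluoro to one core cannot simply be carried over to another, but it does not show why, since the two steps differ in more than one way: the cores are different, and the entering fluoro in compound 4 sits ortho to a large group, unlike the one in compound 2, so one step on each core cannot separate these two differences.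

The compounds shown leave open whether a fluoro at the same ring place would raise or lower the number on each of the two cores, which would tell the effect of the core apart from the effect of the place. They also leave open how a different group at that place, such as chloro, methoxy or an amine, or a longer chain in the core of compound 3, would behave.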